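Chlorophenyl-piperidine valine amides: acyl to phenylurea step

A few compounds are considered here, and "the series" means these few. Any claim that something is new, unique, unknown or untested is made for them only; others in the source may bear on it.

Measured compounds:
compound 1 `CC(C)CCC(=O)N[C@@H](C(=O)N1CCC(c2ccc(Cl)cc2)CC1)C(C)C`, 26 nM
compound 2 `CC(C)C(NC(=O)c1ccccc1)C(=O)N1CCC(c2ccc(F)cc2)CC1`, 423 nM
compound 3 `CC(C)C(=O)NC(C(=O)N1CCC(c2ccc(Cl)cc2)CC1)C(C)C`, 388 nM

In an assay on THP-1 cells for displacement of a labelled ligand from C-C chemokine receptor type 1 (Homo sapiens) (on this read-out lower numbers stand for stronger inhibition and higher numbers for weaker inhibition), compound 1 gives 26 nM, the lowest of the three numbers. Compound 3 gives 388 nM and compound 2 gives 423 nM; both stand well beyond the scatter above compound 1, so compound 1 is the strongest of the measured set in this assay. Among the measured compounds shown here, compound 2 carries a benzoyl-type acyl group on a fluorophenyl core, compound 3 an isopropylcarbonyl on the chlorophenyl core shared with compound 1; neither pair differs from compound 1 in only one place, so no single-point step is available.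

Compound 4 `CC(C)[C@@H](NC(=O)Nc1ccccc1)C(=O)N1CCC(c2ccc(Cl)cc2)CC1` is not yet measured. It differs from compound 1 as follows: anilino in place of isopentyl on a carbonyl carbon. The acyl chain of compound 1 is replaced by a urea bearing a phenyl ring. For the measured compounds named here, the only comparison with an aromatic group on the acyl side is compound 2, which gives a much higher number than compound 1, though on a different core and without the stereocentre fixed. The step is therefore expected to be a 4.6-fold higher number from compound 1 to compound 4 (0.66 log units; beyond the scatter). That expected step is smaller than the gap from compound 1 to compound 2. Compound 4 is estimated at 120 nM, in the range 40 nM to 400 nM.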

Compound 4, half-maximal inhibitory concentration: 616 nM
Beside the measured number, compound 4's estimate is 5.1-fold (0.71 log units) below it; measured number outside the range, above it.
By their numbers in this assay, from the lowest: compound 1; then compounds 3, 2 and 4 (each within the scatter of the next).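

Anilino in place of isopentyl on a carbonyl carbon is the first change in the series that can be read at a single place: in this assay it gives a 24-fold higher number from compound 1 to compound 4 (1.37 log units; beyond the scatter). With the rest of compound 1 unchanged, this shows that the number depends strongly on the group carried on this carbonyl carbon, and that the phenylcarbamoyl group is a poor replacement for isopentylcarbonyl on this core. Nothing at hand shows whether the step comes from the aromatic ring, from the added nitrogen with its hydrogen-bond donor, or from the two together.

Still open, from the compounds shown here alone, is whether a benzyl or cyclohexylamino group on the same carbonyl carbon would stay closer to compound 1, which would help separate the ring from the urea nitrogen. Also open, going by these compounds, is how a longer alkyl chain than isopentyl would read at this position.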